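Adding Diethylamino to the Propyl Chain of Compound 2

The compounds below may be only part of what the source reports. "The series", "measured", "known", "first", "only" and "open" are said of these compounds alone.

Compound 2 `CCCn1c(N)c(-c2nc3ccccc3[nH]2)c2nc(C#N)c(C#N)nc21` carries a plain propyl chain on the shared core. Going by the values given here, in a functional assay on HL-60 cells (Homo sapiens) for antiproliferative activity, read by MTT assay, with a stated time of 48 h (a higher number here means a weaker inhibitor, a lower number a stronger inhibitor), compound 2 gives 45200 nM, the higher of the two numbers measured so far and therefore the weaker result. Compound 1 `CN1CCN(CCn2c(N)c(-c3nc4ccccc4[nH]3)c3nc(C#N)c(C#N)nc32)CC1` gives 4300 nM in this assay. Compound 3 `CCN(CC)CCCn1c(N)c(-c2nc3ccccc3[nH]2)c2nc(C#N)c(C#N)nc21` changes the chain of compound 2: diethylamino in place of hydrogen on a saturated chain carbon, three bonds along the chain from an aromatic nitrogen. Here diethylamino replaces hydrogen on a saturated chain carbon, three bonds along the chain from an aromatic nitrogen, so propyl becomes 3-(diethylamino)propyl.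

Among the compounds with values here, only one measured step bears on this change: an 11-fold higher number from compound 1 to compound 2 (1.02 log units; beyond the scatter). That large step removed 4-methylpiperazin-1-yl, so adding a different nitrogen-containing group may work in reverse, although a single step is a thin guide. The expected change is a large drop, a 9.0-fold lower number from compound 2 to compound 3 (0.96 log units; beyond the scatter). For compound 3 the estimated value is 5000 nM, within an expected range of 1500 nM to 18000 nM.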

Compound 3, half-maximal inhibitory concentration: > 730 nM
Compound 3: no number, only a limit (the forecaster's own chance of this, stated with the estimate: 5%); the middle value lies beyond the limit too.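

In this assay compound 3 gives > 730 nM, which is a limit and not a number, so its steps from compound 1 and from compound 2 cannot be read. The compounds shown leave open whether 3-(diethylamino)propyl gives a stronger or weaker result than propyl.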